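Chloro to Trifluoromethyl on the Aryl Group of Compound 2

The compounds below may be only part of what the source reports. "The series", "measured", "known", "first", "only" and "open" are said of these compounds alone.

Measured compounds:
Compound 1, `Cc1c(-c2cc(Cl)cc(Cl)c2)c(C(=O)O)nn1-c1nc(-c2cc(Cl)ccc2F)c(SC(C)C)s1`: 4800 nM
Compound 2, `Cc1nn(-c2nc(-c3ccc(Cl)c(Cl)c3)c(SC(C)C)s2)c(C(=O)O)c1-c1ccc(Cl)cc1`: 2500 nM

Of the compounds shown here, two sharing the same core have been measured in a functional assay on BJAB cells (Homo sapiens) for antiproliferative activity, with a stated time of 4 days; a higher number here means that more compound is needed for the effect, a lower number that less compound is needed. Compound 1, `Cc1c(-c2cc(Cl)cc(Cl)c2)c(C(=O)O)nn1-c1nc(-c2cc(Cl)ccc2F)c(SC(C)C)s1`, gives 4800 nM in this assay. Compound 2, `Cc1nn(-c2nc(-c3ccc(Cl)c(Cl)c3)c(SC(C)C)s2)c(C(=O)O)c1-c1ccc(Cl)cc1`, gives 2500 nM. Of the two numbers, compound 2 shows the lower one, but the gap between compound 2 and compound 1 is within the usual scatter of this assay, so the two cannot be placed in order on this evidence.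

Compound 3, `Cc1nn(-c2nc(-c3ccc(Cl)c(Cl)c3)c(SC(C)C)s2)c(C(=O)O)c1-c1ccc(C(F)(F)F)cc1`, has not yet been measured. It differs from compound 2 in one place: trifluoromethyl in place of chloro on an aromatic carbon. The change sits on an aromatic carbon of a six-membered aromatic ring of carbon only. Going by the values given here, no measured pair shows what such an exchange does on this core, and the two measured compounds differ from each other in several places at once, so no single-step comparison is available.

With nothing to lean on beyond the two values above, the expected step in this assay, no change at the digits printed from compound 2 to compound 3 (within the scatter), is small, with no clear direction beyond the scatter. Compound 3 is therefore estimated at 2500 nM, in a range from 800 nM to 8000 nM.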

Compound 3, half-maximal effective concentration: 3500 nM
The estimate for compound 3 lay 1.4-fold (0.15 log units) below the measured number; the measured number falls inside the stated range.
By their numbers in this assay, from the lowest: compounds 2, 3 and 1 (each within the scatter of the next).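

In this assay, going by these compounds alone, the exchange of chloro for trifluoromethyl gives a 1.4-fold higher number from compound 2 to compound 3 (0.15 log units; within the scatter) and so supplies the first comparison on the shared core in which only one place differs. On this aromatic carbon, para to a large group, four heavy atoms thus take the place of a single chlorine without a change that can be told apart from the scatter, so this position accepts the larger of these two groups with no readable effect on the number. No measurement is at hand that would explain this result.

The compounds shown leave open whether a group of another kind at this position, such as an amine, a nitrile or a hydroxyl, would carry the number beyond the scatter, since chloro and trifluoromethyl are the only two groups compared here. Also open, going by these compounds, is what an amide in place of the carboxylic acid would do, and how much each of the several differences between compound 1 and compound 2 contributes on its own.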